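This account rests on a few compounds, and the source may have more. Where it says the series, first, only, none or still open, it means among the compounds named here.

Measured so far in a functional assay on L1210 cells (Mus musculus) for cytotoxicity, read by cell counting, with a stated time of 2 days; a lower number here means a stronger inhibitor, a higher number a weaker inhibitor:
compound 1 `C=C(Br)C(=O)Nc1ccc(/C=C2\SC(=O)N(Cc3cccc(F)c3)C2=O)cc1` gives 1200 nM;
compound 2 `C=C(Br)C(=O)Nc1ccc(/C=C2\SC(=O)N(Cc3ccc(C)cc3)C2=O)cc1` gives 3400 nM;
compound 3 `Nc1ccc(/C=C2\SC(=O)N(Cc3ccccc3)C2=O)cc1` gives 38000 nM.

Compound 3 stands highest of the three numbers, above compound 2 and furthest from compound 1, in each case beyond the scatter. Compound 4 `C=C(Br)C(=O)Nc1ccc(/C=C2\SC(=O)N(Cc3ccccc3)C2=O)cc1` differs from compound 3 in one place: (1-bromoethenyl)carbonyl in place of hydrogen on a nitrogen on an aromatic ring. Going by the values given here, no measured step changes this same place. Among the compounds with values here, the one measured step, a 2.8-fold higher number from compound 1 to compound 2 (0.45 log units; beyond the scatter), varies the group on the saturated chain carbon bound to the amide-type nitrogen in the ring, a part compound 4 keeps as in compound 3. Still, compound 1 and compound 2 both carry the entering group and both lie well under compound 3, so a drop of comparable size is expected for compound 4, a 19-fold lower number from compound 3 to compound 4 (1.28 log units; beyond the scatter). Compound 4 is estimated at 2000 nM, range 700 nM to 6000 nM.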

Compound 4, half-maximal inhibitory concentration: 1100 nM
Estimate against measurement, compound 4: 1.8-fold (0.26 log units) above; the measured number falls inside the stated range.
By their numbers in this assay, from the lowest: compounds 4 and 1 (each within the scatter of the next); then compound 2; then compound 3.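

In this assay, going by these compounds alone, the (1-bromoethenyl)carbonyl on the nitrogen on the aromatic ring now has a direct one-place reading (a 35-fold lower number from compound 3 to compound 4 (1.54 log units; beyond the scatter)), which the earlier compounds could only suggest. With that group kept, hydrogen in place of methyl on an aromatic carbon gives a modest step (a 3.1-fold lower number from compound 2 to compound 4 (0.49 log units; beyond the scatter)), whereas hydrogen in place of fluoro gives no step beyond the scatter (a 1.1-fold lower number from compound 1 to compound 4 (0.04 log units; within the scatter)). No supporting data bear on the reason for these differences.

On these data alone, whether the bromine is needed remains open. An acetyl or a plain propenoyl group on the same nitrogen would address this.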